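A few compounds are considered here, and "the series" means these few. Any claim that something is new, unique, unknown or untested is made for them only; others in the source may bear on it.

Measured compounds:
compound 1, `Cc1cc(-c2c(CCc3ccccc3)c3cc(OCC(=O)NC(C)(C)c4ccccc4)ccc3[nH]c2=O)on1`: 31 nM
compound 2, `COCCCNC(=O)COc1ccc2c(c1)c(CCc1ccccc1)c(-c1ccc(F)cc1F)c(=O)n2C`: 633 nM

In a functional assay on CHO cells for antagonist activity at adenosine receptor A2b (Homo sapiens), read by cAMP accumulation, with stated times of 15 min and 1 h (a lower number here means a stronger inhibitor, a higher number a weaker inhibitor), compound 1 gives 31 nM, the lower of the two numbers shown, while compound 2 gives 633 nM, a higher number by a gap that lies beyond the usual scatter. Compound 3, `CC(C)(NC(=O)COc1ccc2[nH]c(=O)c(-c3cccnc3)c(CCc3ccccc3)c2c1)c1ccccc1`, follows from compound 1 by one change: pyridin-3-yl in place of 3-methyl-1,2-oxazol-5-yl on an aromatic carbon. Among the measured compounds shown here, no measured pair shows this change, so its size is not known from the data. A small step is expected, a 1.5-fold higher number from compound 1 to compound 3 (0.16 log units; within the scatter), toward a somewhat higher number but not clearly beyond the scatter. Compound 3 is therefore estimated at 45 nM, within a range from 12 nM to 160 nM.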

Compound 3, inhibition constant: 187 nM
Compound 3: middle estimate off by 4.2-fold (0.62 log units), on the low side, outside the stated range (above it).
By their numbers in this assay, from the lowest: compound 1; then compound 3; then compound 2.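

In this assay, the aromatic carbon ortho to a phenethyl group proves sensitive to which ring it carries: pyridin-3-yl in place of 3-methyl-1,2-oxazol-5-yl gives a 6.0-fold higher number from compound 1 to compound 3 (0.78 log units; beyond the scatter). Two rings of equal heavy-atom count are therefore not interchangeable here, and of these two the 3-methyl-1,2-oxazol-5-yl ring gives the lower number. Nothing available explains this difference. The step changes ring size, hetero atoms and the methyl group together, so their separate contributions remain unresolved. Unsubstituted phenyl, pyridin-4-yl or 1,2-oxazol-5-yl without the methyl at this carbon would be needed to separate them.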